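The source may report more compounds than this note shows. Statements on the series, on what has been measured and on what is new or still open speak of the compounds shown alone.

Going by the values given here, compound 2, `N#Cc1c(NN)nc(SCc2nc3ccccc3[nH]2)nc1-c1ccccc1`, is one of only two compounds measured so far. In a functional assay on NCI-H460 cells (Homo sapiens) for cytotoxicity, read by MTT assay, with a stated time of 3 days (a higher number here means a weaker inhibitor, a lower number a stronger inhibitor), compound 2 gives 2.6 nM. Compound 1, `N#Cc1c(O)nc(SCc2nc3ccccc3[nH]2)nc1-c1ccccc1`, gives 2.5 nM in this assay, and the step of a 1.0-fold higher number from compound 1 to compound 2 (0.02 log units; within the scatter) is within the scatter, so the two numbers cannot be told apart. Compound 3, `CN1CCN(c2nc(SCc3nc4ccccc4[nH]3)nc(-c3ccccc3)c2C#N)CC1`, has not been measured yet. It differs from compound 2 by 4-methylpiperazin-1-yl in place of aminoamino on an aromatic carbon. Among the compounds with values here, the only measured step that touches the same position is a 1.0-fold higher number from compound 1 to compound 2 (0.02 log units; within the scatter), where aminoamino in place of hydroxy left the number unchanged within the scatter. That single step gives no sign that replacing the group at this position moves the number, although it says nothing directly about a group as large as 4-methylpiperazin-1-yl. For compound 3 the expected step is therefore a 1.2-fold higher number from compound 2 to compound 3 (0.06 log units; within the scatter), giving an estimated value of 3 nM with a range from 1 nM to 10 nM.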

Compound 3, half-maximal inhibitory concentration: 2.84 nM
Compound 3: the middle estimate sits 1.1-fold (0.02 log units) above what was measured; low and high end bracket the measured number.
By their numbers in this assay, from the lowest: compounds 1, 2 and 3 (each within the scatter of the next).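

In this assay, this position, next to the ring nitrogen and ortho to a cyano group, accepts a much larger group than the earlier pair could show: 4-methylpiperazin-1-yl brings 7 heavy atoms and a six-membered non-aromatic ring in place of the 2 heavy atoms of aminoamino, yet the change gives a 1.1-fold higher number from compound 2 to compound 3 (0.04 log units; within the scatter). The comparison with hydroxy reads the same, with a 1.1-fold higher number from compound 1 to compound 3 (0.06 log units; within the scatter). The 2 hydrogen-bond donors of aminoamino are also gone in compound 3 without any change beyond the scatter, but no measurement here explains why these swaps make so little difference.

From the compounds shown here alone, whether the number would hold with a carboxylic acid or a long carbon chain at this position remains open. These compounds vary only this one place, so what the phenyl group or the rest of the shared core contributes is also unknown.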